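From Acetoxy to Benzoyloxy on a Shared Core

A few compounds are considered here, and "the series" means these few. Any claim that something is new, unique, unknown or untested is made for them only; others in the source may bear on it.

Of the compounds shown here, two have so far been measured in a physicochemical assay for lipophilicity, read by HPLC, measured as octanol-water partition; a lower number here means a more polar compound, a higher number a more lipophilic compound. Compound 1 `CN(CCC#N)C[C@H]1CN(c2ccc(-n3cc(-c4ccccn4)cn3)c(F)c2)C(=O)O1` gives 1.9. Compound 2 `CC(=O)OC[C@H]1CN(c2ccc(-n3cc(-c4ccccn4)cn3)c(F)c2)C(=O)O1` gives 2.09. Compound 2 stands highest of the two numbers, though its nearest neighbour, compound 1, sits only a little lower, and the step of a number 0.19 log units higher from compound 1 to compound 2 (within the scatter) is within the scatter. A third compound, compound 3 `O=C(OC[C@H]1CN(c2ccc(-n3cc(-c4ccccn4)cn3)c(F)c2)C(=O)O1)c1ccccc1`, has not yet been measured. It differs from compound 2 by phenyl in place of methyl on a carbonyl carbon; cut one bond further out, the same difference reads acetyl to benzoyl, or acetoxy to benzoyloxy. Among the measured compounds shown here, the only measured step concerns an exchange on a saturated chain carbon and brings no ring in or out, so it does not bear directly on this change. Resting only on the number for compound 2 and on the size of the group that enters, compound 3 is expected to lie higher in this assay, with a step of a number 1.61 log units higher from compound 2 to compound 3 (beyond the scatter) expected. Compound 3 is estimated at 3.7, within a range from 3.1 to 4.3.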

Compound 3, partition coefficient: 4.21
Beside the measured number, compound 3's estimate is 0.51 log units below it; the measured number falls inside the stated range.
By their numbers in this assay, from the lowest: compounds 1 and 2 (each within the scatter of the next); then compound 3.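

Phenyl in place of methyl on a carbonyl carbon gives a number 2.12 log units higher from compound 2 to compound 3 (beyond the scatter) in this assay, the first change in this series to lie beyond the scatter. Measured against the (2-cyanoethyl)(methyl)amino group on the saturated chain carbon, acetoxy gives only a number 0.19 log units higher from compound 1 to compound 2 (within the scatter), while benzoyloxy gives a number 2.31 log units higher from compound 1 to compound 3 (beyond the scatter), so the two groups that share this place on the chain differ widely in this assay, and the difference is carried by what stands on the carbonyl carbon. No measurement at hand offers an explanation for the size of this step.

With phenyl as the only large group on the carbonyl carbon, the compounds shown cannot separate the contribution of the aromatic ring from that of the added carbon atoms, and a cyclohexyl group or a longer chain in the same place would be needed to tell these apart. As far as these compounds go, it also remains open whether a pyridyl ring or a phenyl ring carrying an amine or a carboxylic acid would hold the number near that of compound 3 or bring it back towards that of compound 2.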